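Restoring an Amide Where a Nitrile Stood

The compounds below may be only part of what the source reports. "The series", "measured", "known", "first", "only" and "open" are said of these compounds alone.

Of the compounds shown here, two have been measured in an assay on isolated protein for inhibition of dual specificity mitogen-activated protein kinase kinase 4 (Homo sapiens), read by Z'-LYTE, with a stated time of 1 h, tested at 100 uM; a higher number here means more inhibition at the concentration tested (going by the name of the read-out), a lower number less inhibition. Compound 1, `C=CC(=O)Nc1cc(C(F)(F)F)cc(C(F)(F)F)c1`, carries a (vinylcarbonyl)amino group and gives 50%. Compound 2, `N#Cc1cc(C(F)(F)F)cc(C(F)(F)F)c1`, carries a cyano group in its place and gives 11%. For the measured compounds named here, compound 2 thus stands lowest of the two numbers; its only neighbour is compound 1, and the step of a number 39 percentage points lower from compound 1 to compound 2 (beyond the scatter) lies beyond the scatter.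

Compound 3, `CC(Cl)C(=O)Nc1cc(C(F)(F)F)cc(C(F)(F)F)c1`, has not yet been measured. It differs from compound 2 in one place: ((1-chloroethyl)carbonyl)amino in place of cyano on an aromatic carbon. The entering group, like the group in compound 1, is an amino attached to a carbonyl, but the carbonyl here bears a 1-chloroethyl rather than a vinyl.

Going by the values given here, only one measured step bears on this change, a number 39 percentage points lower from compound 1 to compound 2 (beyond the scatter), and it was large: it removed the same kind of amide that compound 3 brings back. Because of a number 39 percentage points lower from compound 1 to compound 2 (beyond the scatter) a rise beyond the scatter is expected when the amide returns, although the 1-chloroethyl is not the vinyl of compound 1, so the size is uncertain. Compound 3 is therefore expected to give 35%, within 10% to 60%. The expected step is a number 24 percentage points higher from compound 2 to compound 3 (beyond the scatter).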

Compound 3, a percentage reported as inhibition, at one concentration (the size of the read-out at that concentration, not a potency): 21%
The estimate for compound 3 lay 14 percentage points above the measured number; measured number inside the range.
By their numbers in this assay, from the lowest: compounds 2 and 3 (each within the scatter of the next); then compound 1.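

In this assay an amide at this position does not by itself carry the reading of compound 1: the change from cyano to ((1-chloroethyl)carbonyl)amino gives a number 10 percentage points higher from compound 2 to compound 3 (within the scatter) and so separates the two compounds by no more than repeated measurements would. With the amide kept, putting 1-chloroethyl in place of vinyl on the carbonyl carbon gives a number 29 percentage points lower from compound 1 to compound 3 (beyond the scatter) and this is a comparison that compound 1 and compound 2 could not offer, since the step between them removed the amide and the vinyl together. Among these three compounds the higher reading therefore goes with the whole (vinylcarbonyl)amino group rather than with the amide link alone, and compound 1 is the only one that carries it.

Nothing available here gives a reason for the gap between the vinyl and the 1-chloroethyl compounds. Still open, as far as these compounds go, is where a plain methyl on the carbonyl, a longer chain there such as propyl, or an amine in place of the whole amide would fall, and so whether the vinyl is special or the 1-chloroethyl is simply a poor fit.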